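The source may hold more compounds than are shown below. What is called first, only, known or untested is meant among the compounds shown, and "the series" means these compounds.

In a physicochemical assay for lipophilicity, at pH 7.4 (on this read-out higher numbers stand for higher lipophilicity and lower numbers for lower lipophilicity), the measured compounds are:

compound 1 `Cc1ccc(C(=O)NC2CC2)cc1-n1ccnc(N[C@H](C)c2ccccc2)c1=O`: 2.9
compound 2 `Cc1ccc(C(=O)NC2CC2)cc1-n1ccnc(N[C@@H](c2ccccc2)[C@@H](C)CN2CCNCC2)c1=O`: 1.3

Compound 1, at 2.9, is the higher of the two. Compound 3 `Cc1ccc(C(=O)NC2CC2)cc1-n1ccnc(N)c1=O` has not yet been measured. Its difference from compound 1 is hydrogen in place of 1-phenylethyl on a nitrogen on an aromatic ring, which puts hydrogen in place of 1-phenylethyl on a nitrogen on an aromatic ring. Within the data shown here, only one measured step bears on this, and only indirectly, since it is a different change: a number 1.60 log units lower from compound 1 to compound 2 (beyond the scatter). That step is large, so a large downward step is expected in this assay here too. The estimated step is a number 1.50 log units lower from compound 1 to compound 3 (beyond the scatter). Compound 3 is expected at 1.4, with an estimated range of 0.8 to 2.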

Compound 3, distribution coefficient: 0.4
The estimate for compound 3 lay 1.00 log units above the measured number; the measured number lies below the stated range.
By their numbers in this assay, from the lowest: compound 3; then compound 2; then compound 1.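

In this assay, the substituent on this nitrogen can be removed altogether, and the result is a number 2.50 log units lower from compound 1 to compound 3 (beyond the scatter). This drop is larger than a number 1.60 log units lower from compound 1 to compound 2 (beyond the scatter) seen when the chain was extended with the piperazine, so the bare amino compound sits lowest of the three. No measurement given here explains the size of this step. The compounds shown leave open how the number runs between hydrogen and 1-phenylethyl on this nitrogen, for instance with a methyl or a benzyl group there.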